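Shifting the aryl substituent: fluoro to methoxy

The source may hold more compounds than are shown below. What is called first, only, known or untested is meant among the compounds shown, and "the series" means these compounds.

Among the three measured compounds, compound 3 `Cc1cc2nc(NC(=O)c3cc(-c4ccc(F)cc4)n4nc(-c5ccccc5)cc4n3)sc2cc1C` stands second highest in a functional assay on MCF7 cells (Homo sapiens) for cytotoxicity, read by MTT assay, with a stated time of 48 h (on this read-out lower numbers stand for stronger inhibition and higher numbers for weaker inhibition), giving 17000 nM. Compound 1 `COc1ccc(-c2cc(C(=O)Nc3nc4ccc(F)cc4s3)nc3cc(-c4ccccc4)nn23)cc1` gives 35500 nM in this assay, and compound 2 `COc1ccc(-c2cc(C(=O)Nc3nc4ccccc4s3)nc3cc(-c4ccccc4)nn23)cc1` gives 2230 nM. Among the measured compounds shown here, the only single-site step measured, a 16-fold lower number from compound 1 to compound 2 (1.20 log units; beyond the scatter), concerns the fused ring and not the aryl group that changes here. The step to compound 4 `COc1ccc(-c2cc(C(=O)Nc3nc4cc(C)c(C)cc4s3)nc3cc(-c4ccccc4)nn23)cc1` is methoxy in place of fluoro on an aromatic carbon. For the measured compounds named here, no measured pair isolates this exchange, so the expectation rests on an indirect comparison: compound 4 carries the same methoxyphenyl as compound 2, and in this assay compound 2 gives 2230 nM, against compound 3 with the fluorophenyl giving 17000 nM; the two also differ on the fused ring, so the comparison is indirect. For compound 4 a lower number is expected in this assay, estimated at 6000 nM with a range from 2000 nM to 20000 nM. The step from compound 3 to compound 4 is therefore expected to be a 2.8-fold lower number from compound 3 to compound 4 (0.45 log units; beyond the scatter).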

Compound 4, half-maximal inhibitory concentration: 19700 nM
Compound 4: middle estimate off by 3.3-fold (0.52 log units), on the low side; low and high end bracket the measured number.
By their numbers in this assay, from the lowest: compound 2; then compounds 3, 4 and 1 (each within the scatter of the next, the first and the last beyond it).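

In this assay, 4-fluorophenyl and 4-methoxyphenyl can now be compared directly on the same 5,6-dimethyl-1,3-benzothiazol-2-yl amide, and the exchange gives a 1.2-fold higher number from compound 3 to compound 4 (0.06 log units; within the scatter), so the two groups are not told apart at this position. With 4-methoxyphenyl held in place, the fused ring still separates the compounds: going to the 5,6-dimethyl form gives an 8.8-fold higher number from compound 2 to compound 4 (0.95 log units; beyond the scatter), whereas the 6-fluoro and 5,6-dimethyl forms are not told apart, at a 1.8-fold lower number from compound 1 to compound 4 (0.26 log units; within the scatter).

The compounds shown leave open whether the aryl exchange would read the same on the 1,3-benzothiazol-2-yl amide, where the number is lowest. They also leave open how an amine or a carboxylic acid would read in place of the methoxy group. Nothing at hand offers an explanation for these numbers.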